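The compounds below may be only part of what the source reports. "The series", "measured", "known", "first", "only" and "open" are said of these compounds alone.

Compound 1 `C/C=C1/[C@H](O[C@@H]2O[C@H](CO)[C@@H](O)[C@H](O)[C@H]2O)OC=C(C(=O)OC)[C@H]1CC(=O)OCCc1ccc(OC)c(OC)c1` is the starting point. In a functional assay on SK-BR-3 cells (Homo sapiens) for antiproliferative activity, read by MTT assay, with a stated time of 72 h (a lower number here means a stronger inhibitor, a higher number a weaker inhibitor), compound 1 reaches only the limit of the measurement, > 15000 nM, so it has no number of its own, just a bound. Two companions share the core. Compound 2 `C/C=C1/[C@H](O[C@@H]2O[C@H](COC(C)=O)[C@@H](OC(C)=O)[C@H](OC(C)=O)[C@H]2OC(C)=O)OC=C(C(=O)OC)[C@H]1CC(=O)SCCC` carries a propylsulfanyl on a carbonyl carbon. In this assay compound 2 likewise sits at the limit, > 15000 nM. Compound 3 `C/C=C1/[C@H](O[C@@H]2O[C@H](COC(C)=O)[C@@H](OC(C)=O)[C@H](OC(C)=O)[C@H]2OC(C)=O)OC=C(C(=O)OC)[C@H]1CC(=O)OC` has a methoxy in place of the propylsulfanyl on a carbonyl carbon. In this assay compound 3 also stops at the limit, > 15000 nM. For the measured compounds named here, the one measured step, a step that the two limits leave unreadable from compound 2 to compound 3, cannot be sized, and all three results agree only in the limit of > 15000 nM in this assay, at which 3 of the 3 values shown sit.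

Compound 4 `C/C=C1/[C@H](O[C@@H]2O[C@H](CO)[C@@H](O)[C@H](O)[C@H]2O)OC=C(C(=O)OC)[C@H]1CC(=O)OCCc1ccc(F)cc1` differs from compound 1 in one place: 4-fluorophenyl in place of 3,4-dimethoxyphenyl on a saturated chain carbon, two bonds along the chain from an oxygen next to a carbonyl group. Going by the values given here, no measured step touches this change, and the single step known lies elsewhere on the core and could not be sized. Nothing among the three compounds gives a reason to expect the limit to be cleared. Compound 4 is therefore expected to remain at the limit as well, with an estimate of 20000 nM inside 8000 nM to 60000 nM. The step that this estimate means, a step that the limit leaves unreadable from compound 1 to compound 4, is expected to stay within the uncertainty of two bounds, and most likely only a limit will be recorded again.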

Compound 4, half-maximal inhibitory concentration: > 20000 nM
Compound 4 ended at the assay's limit; the forecaster's own chance of this, stated with the estimate: 80%; the middle value lies on the limit itself.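

For the compounds shown here, compound 1 and compound 4 each stop at a limit in this assay rather than at a number, so placing 4-fluorophenyl in place of 3,4-dimethoxyphenyl yields no step that can be read. The compounds shown leave open whether anything on the shared core gives a value of its own in this assay.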